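The compounds below may be only part of what the source reports. "The series", "measured", "known", "first", "only" and "open" are said of these compounds alone.

Measured compounds:
compound 1 `COc1cc(C(=O)N/N=C/c2cccc(F)c2)cc(OC)c1OC`, 44.8%
compound 2 `COc1cc(C(=O)N/N=C/c2cccc(C(F)(F)F)c2)cc(OC)c1OC`, 33.8%
compound 3 `COc1ccc(OC)c(C2OC(c3cc(OC)c(OC)c(OC)c3)=NN2C(C)=O)c1`, 18.2%

The three compounds were tested in a functional assay on BGC-823 cells (Homo sapiens) for antiproliferative activity, read by MTT assay, tested at 5 uM; a lower number here means a weaker effect, a higher number a stronger effect of the compound at the concentration tested. Compound 1 gives 44.8%, compound 2 gives 33.8%, and the change a number 11 percentage points lower from compound 1 to compound 2 (beyond the scatter). Compound 3 gives 18.2%, the lowest of the three numbers and beyond the scatter from both of the others.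

Compound 4 `COc1cc(C2=NN(C(C)=O)C(c3cccc(F)c3)O2)cc(OC)c1OC` has not yet been measured. It differs from compound 3 in one place: 3-fluorophenyl in place of 2,5-dimethoxyphenyl on a saturated ring carbon.

Going by the values given here, none of the measured steps covers this particular exchange. Among the compounds with values here, the only step that was measured, from compound 1 to compound 2, concerns a fluoro group exchanged for trifluoromethyl on an open-chain core, not a change on the saturated ring carbon of the shared core of compound 3. What can be noted is that compound 1, which also carries a 3-fluorophenyl group, gives 44.8%, the highest number of the three, while compound 3 with its 2,5-dimethoxyphenyl group gives 18.2%. On that thin basis a rise is expected for compound 4, a number 8.8 percentage points higher from compound 3 to compound 4 (within the scatter), though the uncertainty is wide. The expected value for compound 4 in this assay is 27%, within a range of 10% to 45%.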

Compound 4, a percentage reported as inhibition, at one concentration (the size of the read-out at that concentration, not a potency): 37.7%
The estimate for compound 4 lay 10.7 percentage points below the measured number; low and high end bracket the measured number.
By their numbers in this assay, from the lowest: compound 3; then compounds 2, 4 and 1 (each within the scatter of the next, the first and the last beyond it).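

In this assay, going by these compounds alone, the aromatic group on the saturated ring carbon of the shared core turns out to matter: with the rest of the molecule unchanged, exchanging 2,5-dimethoxyphenyl for 3-fluorophenyl gives a number 19.5 percentage points higher from compound 3 to compound 4 (beyond the scatter), the first measured change at this position. The group that enters is the smaller of the two, with fewer heavy atoms, and it has 0 hydrogen-bond acceptors against 2, so this single exchange alters size, acceptor count and substitution pattern together. No measurement shown here explains the rise, so the step records what happened and not the reason for it.

The exchange removes both methoxy groups and introduces the fluoro group in one move, so the compounds shown cannot separate the contribution of each of these changes. Still open, as far as these compounds go, is how the position responds to an unsubstituted phenyl ring, to a phenyl ring bearing a single methoxy group, or to a phenyl ring carrying an amine or a carboxylic acid.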